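A Second Pyrrolidinyl Position Weighed Against Compound 1

A few compounds are considered here, and "the series" means these few. Any claim that something is new, unique, unknown or untested is made for them only; others in the source may bear on it.

Compound 1 `c1ccc(NCc2ccc(CNc3ncccn3)cc2)cc1` was measured in an assay on MDA-MB-231 cells for displacement of a labelled ligand from C-X-C chemokine receptor type 4 (Homo sapiens) (a higher number here means that more compound is needed for the effect, a lower number that less compound is needed), where compound 1 gives 10 nM. Two compounds that differ from it in a single place read the same: compound 2 `c1cnc(NCc2ccc(CNc3cccc(N4CCCC4)c3)cc2)nc1` gives 10 nM and compound 3 `Clc1ccc(NCc2ccc(CNc3ncccn3)cc2)nc1` gives 10 nM. The steps confirm this: no change at the digits printed from compound 1 to compound 2 (within the scatter) and no change at the digits printed from compound 1 to compound 3 (within the scatter). Compound 1 therefore stands level with compounds 2 and 3 at the digits shown, compound 2 being nearest and compound 3 furthest, although neither gap is beyond the scatter.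

Compound 4 `c1cnc(NCc2ccc(CNc3ccccc3N3CCCC3)cc2)nc1` has not yet been measured. It differs from compound 1 as follows: pyrrolidin-1-yl in place of hydrogen on an aromatic carbon The entering group is pyrrolidin-1-yl, set on an aromatic carbon of a six-membered aromatic ring of carbon only, ortho to a large group. The measured step that bears on it is the one in which the same group enters on an aromatic carbon, no change at the digits printed from compound 1 to compound 2 (within the scatter), which showed no change beyond the scatter. Among the compounds with values here, no measured step probes a place ortho to a large group, so the expectation rests on that single step alone. The expected step is no change at the digits printed from compound 1 to compound 4 (within the scatter), meaning none beyond the scatter. Compound 4 is estimated at 10 nM, with a range from 4 nM to 30 nM.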

Compound 4, effective concentration (reported as EC, without a stated level of effect): 100 nM
Compound 4: middle estimate off by 10-fold (1.00 log units), on the low side, outside the stated range (above it).
By their numbers in this assay, from the lowest: compounds 1, 2 and 3 (each within the scatter of the next); then compound 4.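

In this assay, the entry of pyrrolidin-1-yl on an aromatic carbon had given no change at the digits printed from compound 1 to compound 2 (within the scatter), so a single step made the group look freely accepted on that ring. The same group, set ortho to a large group, gives a 10-fold higher number from compound 1 to compound 4 (1.00 log units; beyond the scatter), which means that more compound is needed for the same effect. The group's presence alone therefore does not decide the outcome: compound 2 gives 10 nM and compound 4 gives 100 nM, with the same group entering at a different place on the ring, so a step read at one place on this ring does not carry over to the other.

Still open, going by these compounds, is whether this place reacts to any group at all or to pyrrolidin-1-yl in particular, since a methyl, a methoxy or a dimethylamino group at the same place would separate those two readings. What lies behind the higher number also stays open, as nothing shown here gives any measured explanation for it.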